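This account rests on a few compounds, and the source may have more. Where it says the series, first, only, none or still open, it means among the compounds named here.

Compound 1 `CCn1c(=O)c(C(=O)N(C)c2ccccc2)c(O)c2cc(SC)ccc21` and compound 2 `COCn1c(=O)c(C(=O)N(C)c2ccccc2)c(O)c2cc(SC)ccc21` share one core and differ in one place. In a functional assay on the whole organism for inhibition, with Mus musculus as the target, at a dose of 32 mg/kg by the oral route (on this read-out higher numbers stand for more inhibition at the one dose given (going by the name of the read-out) and lower numbers for less inhibition), compound 1 gives 83%, and compound 2 gives 78%, the lower of the two numbers; the step of a number 5 percentage points lower from compound 1 to compound 2 (within the scatter) lies within the scatter. Compound 3 `CSc1ccc2c(c1)c(O)c(C(=O)N(C)c1ccccc1)c(=O)n2Cc1ccccc1` carries phenyl in place of methoxy on a saturated chain carbon bound to an aromatic nitrogen. Among the measured compounds shown here, only that one step is at hand, it concerns a different group at the same place, and it was small, so no shift beyond the scatter is expected here. Compound 3 is estimated at 75%, between 55% and 92%, a step of a number 3 percentage points lower from compound 2 to compound 3 (within the scatter).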

Compound 3, a percentage reported as inhibition, in the whole organism at one dose (the size of the read-out at that dose, not a potency): -66%
For compound 3 the middle estimate is 141 percentage points above the measured one; the measured number lies below the stated range.
By their numbers in this assay, from the lowest: compound 3; then compounds 2 and 1 (each within the scatter of the next).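

In this assay, this place on a saturated chain carbon bound to an aromatic nitrogen proves far from indifferent to what it carries: phenyl in place of methoxy gives a number 144 percentage points lower from compound 2 to compound 3 (beyond the scatter), and phenyl in place of methyl gives a number 149 percentage points lower from compound 1 to compound 3 (beyond the scatter). The methoxy for methyl exchange stayed within the scatter, so this sensitivity appears only with phenyl, and compound 3 even reaches a negative number, -66%. Nothing at hand explains this result. From the compounds shown here alone, whether a cyclohexyl ring, a pyridyl ring or a butyl chain at this place would behave like phenyl stays open.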